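Notes on chain variation at the aromatic nitrogen

A few compounds are considered here, and "the series" means these few. Any claim that something is new, unique, unknown or untested is made for them only; others in the source may bear on it.

Measured so far:
Compound 1 `COc1cc(Cc2nc3c(N)ncnc3n2CC(C)CO)cc(OC)c1OC` gives 49100000 nM in a functional assay on MCF7 cells (Homo sapiens) for cytotoxicity; a higher number here means that more compound is needed for the effect, a lower number that less compound is needed.
Compound 2 `COCCCn1c(Cc2cc(OC)c(OC)c(OC)c2)nc2c(N)nc(F)nc21` gives 72600000 nM in this assay.

Compound 2 carries the highest of the two numbers in this assay; the nearest is compound 1, and the gap between them lies within the scatter, so the two compounds read as equivalent on the evidence shown. Going by the values given here, no pair of measured compounds differs in a single place, so the series provides no measured step to lean on.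

Compound 3 `CC#CCCn1c(Cc2cc(OC)c(OC)c(OC)c2)nc2c(N)nc(F)nc21` is not yet measured. It differs from compound 2 by prop-1-yn-1-yl in place of methoxymethyl on a saturated chain carbon, two bonds along the chain from an aromatic nitrogen. Among the compounds with values here, nothing among the measured compounds tests a change of this kind, and the two measured numbers themselves sit in the same region, so the expectation rests on that region alone. For compound 3 the step from compound 2 is expected to be a 1.2-fold lower number from compound 2 to compound 3 (0.08 log units; within the scatter), that is, none beyond the scatter. Compound 3 is accordingly estimated at 60000000 nM in this assay, with a range from 15000000 nM to 250000000 nM.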

Compound 3, half-maximal effective concentration: 95500000 nM
Compound 3: the middle estimate sits 1.6-fold (0.20 log units) below what was measured; low and high end bracket the measured number.
By their numbers in this assay, from the lowest: compounds 1, 2 and 3 (each within the scatter of the next).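

In this assay, going by these compounds alone, prop-1-yn-1-yl in place of methoxymethyl on a saturated chain carbon, two bonds along the chain from an aromatic nitrogen, gives a 1.3-fold higher number from compound 2 to compound 3 (0.12 log units; within the scatter) and so provides the first measured step at this position, one that stays within the scatter. Compound 2 and compound 3 therefore read as equivalent, and at this place the group with an oxygen and a hydrogen-bond acceptor can be exchanged for the all-carbon group with a triple bond and no hydrogen-bond acceptor without a difference that the measurement can resolve. Nothing in the data at hand accounts for this outcome.

This single exchange does not show whether the chain position is insensitive in general, since a chain ending in an amine or a carboxylic acid, or a longer chain, could still behave differently from compound 2 and compound 3. Within the data shown here, whether any change at this position can move the number in this assay beyond the scatter, in either direction, also remains open, because the one measured step here covers only a swap between two groups with the same count of heavy atoms.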